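The source may hold more compounds than are shown below. What is called first, only, known or untested is meant among the compounds shown, and "the series" means these compounds.

Of the compounds shown here, two with a shared core have been measured so far in a functional assay on the whole organism (Central nervous system) with Mus musculus as the target; a higher number here means that more compound is needed for the effect, a lower number that less compound is needed. Compound 1 `O=C1CCC2(c3ccc(F)cc3)OCCCN12` gives 100 mg/kg, and compound 2 `O=C1CCC2(c3ccc(Cl)cc3)OCCCN12` gives 81.2 mg/kg. Going by the values given here, compound 2 therefore holds the lowest of the two numbers, but the only step between them, a 1.2-fold lower number from compound 1 to compound 2 (0.09 log units; within the scatter), is within the usual scatter, so the two cannot be told apart on these data.

Compound 3 `Cc1ccc(C23CCC(=O)N2CCCO3)cc1` is the next compound in this series, and it differs from compound 2 by a single change on the aromatic ring: methyl in place of chloro on an aromatic carbon. Among the compounds with values here, no measured step involves a methyl group, so the only step that bears on this change is a 1.2-fold lower number from compound 1 to compound 2 (0.09 log units; within the scatter), the exchange of one halogen for another at the same position, which left the number essentially unchanged. On that basis no step beyond the scatter is expected for compound 3 in this assay, so the estimated step is a 1.0-fold higher number from compound 2 to compound 3 (0.02 log units; within the scatter). Compound 3 is thus expected to give about 85 mg/kg, with a range from 45 mg/kg to 160 mg/kg.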

Compound 3, dose for half-maximal effect: 160 mg/kg
Beside the measured number, compound 3's estimate is 1.9-fold (0.27 log units) below it; the range from low to high includes it.
By their numbers in this assay, from the lowest: compounds 2, 1 and 3 (each within the scatter of the next).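

Compound 3 puts a methyl on the aromatic carbon para to a large group, so this position now carries something other than a halogen in this assay. Methyl in place of chloro gives a 2.0-fold higher number from compound 2 to compound 3 (0.29 log units; within the scatter), and methyl in place of fluoro gives a 1.6-fold higher number from compound 1 to compound 3 (0.20 log units; within the scatter); the three groups therefore cannot be told apart here, and across compounds 1, 2 and 3 no exchange at this position has yet produced a step beyond the scatter. No information is available that would account for these numbers.

From the compounds shown here alone, all three groups are small, each entering or leaving as a single heavy atom, so it remains open whether an amine, a carboxylic acid or a longer chain at this position would produce a step beyond the scatter. Going by these compounds, it is also open whether the number responds more clearly to changes elsewhere on the shared core than to any exchange on the aromatic ring.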